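The source may hold more compounds than are shown below. What is called first, only, known or untested is meant among the compounds shown, and "the series" means these compounds.

The measured compounds in an ADME assay on cells (Hepatocyte, Homo sapiens) for metabolic stability, read by LC-MS, with a stated time of 60 min, tested at 1 uM; on this read-out higher numbers stand for fast clearance and lower numbers for slow clearance:
Compound 1, `COc1cc(N(CC2CC2)c2cc(C(F)(F)F)ccc2F)cnc1C(=O)[C@H]1C[C@@H]1C(=O)O`, gives < 1.1 uL/min, which is a limit of the assay rather than a number.
Compound 2, `COc1cc(N(CC2CC2)c2cc(Cl)c(F)cc2F)cnc1C(=O)[C@H]1C[C@@H]1C(=O)O`, gives < 1.5 uL/min, also a limit of the assay.
Compound 3, `COc1cc(N(CC(C)C)c2cc(C(F)(F)F)ccc2F)cnc1C(=O)[C@H]1C[C@@H]1C(=O)O`, gives 3.9 uL/min.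

All three share a core with a carboxylic acid on a small ring and a substituted aromatic amine. Compound 1 and compound 3 differ in one place only: isopropyl in place of cyclopropyl on a saturated chain carbon bound to a nitrogen on an aromatic ring. That single change gives an at least 3.5-fold higher number from compound 1 to compound 3 (0.54 log units; beyond the scatter). The step can be stated only as a lower bound because the limit of < 1.1 uL/min in this assay, at which 1 of the 3 values shown sits, marks where compound 1 sits. Compound 2 and compound 1 differ in more than one place, and the difference between the two cores is not broken down here.

Compound 4, `COc1cc(N(CC(C)C)c2cc(Cl)c(F)cc2F)cnc1C(=O)[C@H]1C[C@@H]1C(=O)O`, has not been measured. It stands to compound 2 exactly as compound 3 stands to compound 1, the same change at the same place: isopropyl in place of cyclopropyl on a saturated chain carbon bound to a nitrogen on an aromatic ring. The starting point for compound 2 is itself known only as a ceiling, as the limit of < 1.5 uL/min in this assay, at which 1 of the 3 values shown sits, shows. The expectation for compound 4 rests on the change being identical in kind and place, so the step from compound 2 to compound 4 is estimated as an at least 3.0-fold higher number from compound 2 to compound 4 (0.47 log units; beyond the scatter), set beside the measured at least 3.5-fold higher number from compound 1 to compound 3 (0.54 log units; beyond the scatter). In this assay compound 4 is therefore expected to give about 4.5 uL/min, most likely between 1.5 uL/min and 13 uL/min.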

Compound 4, intrinsic clearance in a liver preparation (reported as CLH), per the amount of preparation that the assay uses: 4.9 uL/min
Compound 4: the middle estimate sits 1.1-fold (0.04 log units) below what was measured; measured number inside the range.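

In this assay, isopropyl in place of cyclopropyl on a saturated chain carbon bound to a nitrogen on an aromatic ring gives an at least 3.2-fold higher number from compound 2 to compound 4 (0.51 log units; beyond the scatter), so the change moves the read-out the same way on the second core as on the first. Set side by side, the two steps read: the same change on two cores in this assay, an at least 3.5-fold higher number (0.54 log units; beyond the scatter) from compound 1 to compound 3 and an at least 3.2-fold higher number (0.51 log units; beyond the scatter) from compound 2 to compound 4; the limit leaves it open whether they differ. Compound 1 and compound 2 both sit at a limit of the assay rather than at a number, so each step is known only as a lower bound, and two pairs show a shared direction on these two cores without establishing a rule for every core in the series.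

The compounds shown leave open how clearance responds to other groups in the same place, such as a straight propyl chain or cyclobutylmethyl, since only cyclopropylmethyl and isobutyl appear there. They also leave open whether the same step would appear on a core carrying a primary amide in place of the carboxylic acid, or with a nitrile on the aromatic ring in place of the trifluoromethyl or chlorine.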